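Trading One Tetrazole for Another on a Shared Core

This account rests on a few compounds, and the source may have more. Where it says the series, first, only, none or still open, it means among the compounds named here.

In an ADME assay on HUVEC cells (Homo sapiens) for cytotoxicity (on this read-out lower numbers stand for stronger inhibition and higher numbers for weaker inhibition), compound 1 (`CCC(C)n1ncn(-c2ccc(N3CCN(c4ccc(OC[C@@H]5CO[C@@](Cn6cnnn6)(c6ccc(Cl)cc6Cl)O5)cc4)CC3)cc2)c1=O`) gives 73000 nM and compound 2 (`CCC(C)n1ncn(-c2ccc(N3CCN(c4ccc(OC[C@@H]5CO[C@@](Cn6ncnn6)(c6ccc(Cl)cc6Cl)O5)cc4)CC3)cc2)c1=O`) gives 124000 nM. Going by the values given here, these are the only two measured numbers, and they lie within the usual scatter of each other, so neither can be ranked above the other. Compound 3 (`CCC(C)n1ncn(-c2ccc(N3CCN(c4ccc(OC[C@@H]5CO[C@@](Cn6nnnc6C)(c6ccc(Cl)cc6Cl)O5)cc4)CC3)cc2)c1=O`) keeps the shared core and alters a single group: 5-methyl-1H-tetrazol-1-yl in place of 2H-tetrazol-2-yl on a saturated chain carbon bound to a saturated ring carbon. In words, 5-methyl-1H-tetrazol-1-yl stands in place of 2H-tetrazol-2-yl on a saturated chain carbon bound to a saturated ring carbon. Among the compounds with values here, only one measured step bears on this change. Exchanging the two unsubstituted tetrazole groups gave a 1.7-fold higher number from compound 1 to compound 2 (0.23 log units; within the scatter), so that exchange alone offers no reason to expect a real shift. Within the data shown here, no measured pair shows what the extra methyl does, which leaves the range wide. A step beyond the scatter is therefore not expected in this assay, in either direction. The expected change is a 1.3-fold lower number from compound 2 to compound 3 (0.12 log units; within the scatter). For compound 3 the estimated value is 95000 nM, with an expected range from 45000 nM to 180000 nM.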

Compound 3, half-maximal inhibitory concentration: 101000 nM
Beside the measured number, compound 3's estimate is 1.1-fold (0.03 log units) below it, within the range that was stated.
By their numbers in this assay, from the lowest: compounds 1, 3 and 2 (each within the scatter of the next).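

In this assay, putting 5-methyl-1H-tetrazol-1-yl in place of 2H-tetrazol-2-yl on a saturated chain carbon bound to a saturated ring carbon gives a 1.2-fold lower number from compound 2 to compound 3 (0.09 log units; within the scatter), so this read-out does not separate the two groups. The methyl can now also be read on its own, as methyl in place of hydrogen on an aromatic carbon, and this single change gives a 1.4-fold higher number from compound 1 to compound 3 (0.14 log units; within the scatter), so one extra methyl on the tetrazole shows no real shift here either. All three tetrazole variants at this position therefore lie within the scatter of one another, and no supporting measurement is available to explain why they read alike.

Still open, on these data alone, is whether a group of a different kind at this place, such as an amine or a carboxylic acid, would move the number beyond the scatter. As far as these compounds go, it is also open whether a longer chain such as ethyl or propyl in place of the methyl would do so, since a single small methyl says little about larger groups on the tetrazole.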